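Dichloro for difluoro on the triazole aryl group

A few compounds are considered here, and "the series" means these few. Any claim that something is new, unique, unknown or untested is made for them only; others in the source may bear on it.

Three analogues of the shared core, compound 1 `C#CCOc1ccc(/C=C/C(C)=O)cc1OC`, compound 2 `COc1cc(/C=C/C(C)=O)ccc1OCc1cn(-c2c(F)cccc2F)nn1` and compound 3 `COc1cc(/C=C/C(C)=O)ccc1OCc1cn(-c2ccc(/N=N/c3ccccc3)cc2)nn1`, have been measured in a functional assay on PC-3 cells (Homo sapiens) for antiproliferative activity, read by MTT assay, with a stated time of 48 h; a lower number here means a stronger inhibitor, a higher number a weaker inhibitor. In this assay, within the data shown here, compound 2 gives 24200 nM; compound 1 gives 40200 nM and compound 3 gives 42100 nM, so all three numbers sit within the scatter of one another, and no step between measured compounds can be drawn from them. Compound 4 `COc1cc(/C=C/C(C)=O)ccc1OCc1cn(-c2c(Cl)cccc2Cl)nn1` differs from compound 2 by one change: 2,6-dichlorophenyl in place of 2,6-difluorophenyl on an aromatic nitrogen. Among the measured compounds shown here, with no measured step to lean on, compound 4 is expected to stay close to compound 2, with the estimated step of a 1.2-fold lower number from compound 2 to compound 4 (0.08 log units; within the scatter) not reaching beyond the scatter in either direction. For compound 4 the estimate in this assay is 20000 nM, within 8000 nM to 50000 nM.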

Compound 4, half-maximal inhibitory concentration: 3070 nM
Compound 4: the middle estimate sits 6.5-fold (0.81 log units) above what was measured, and the stated range ends above it.
By their numbers in this assay, from the lowest: compound 4; then compounds 2, 1 and 3 (each within the scatter of the next).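

Among these compounds, the aryl group on an aromatic nitrogen is the first place where a single change moves the number beyond the scatter: 2,6-dichlorophenyl in place of 2,6-difluorophenyl gives a 7.9-fold lower number from compound 2 to compound 4 (0.90 log units; beyond the scatter) in this assay. The two groups match in heavy atoms, hydrogen-bond donors and acceptors, so the step goes with the swap of fluorine for chlorine, which compound 1, compound 2 and compound 3 could not reveal. No measurement at hand explains the step.

Open, from the compounds shown here alone, is whether both chlorines are needed, as a 2-chlorophenyl group would test. Also open, going by these compounds, is how far the trend runs, as 2,6-dibromophenyl would show.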